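Half-life notes: an added amide chain on the shared core

The compounds below may be only part of what the source reports. "The series", "measured", "known", "first", "only" and "open" are said of these compounds alone.

Compound 1 `CNc1ncnc2c1ncn2[C@@H]1O[C@H](CN(C)C/C=C\CN)[C@H]2OC(C)(C)O[C@H]21`: > 1.5 h
Compound 2 `CN(C/C=C\CN)C[C@H]1O[C@@H](n2cnc3cncnc32)[C@@H]2OC(C)(C)O[C@@H]21`: > 1.5 h

In an ADME assay on microsomes from liver (Homo sapiens) for metabolic stability, read by LC-MS, using NADPH, tested at 1 uM (on this read-out lower numbers stand for a shorter-lived compound and higher numbers for a longer-lived compound), compound 2 gives > 1.5 h, which is a limit of the assay and not a number. Compound 1 gives > 1.5 h in this assay, and this too is only a limit. Compound 2 therefore stands at the limit of > 1.5 h in this assay, at which 2 of the 2 values shown sit, with no number to measure a change from.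

Compound 3 `CCCCCCCCC(=O)Nc1ncnc2c1ncn2[C@@H]1O[C@H](CN(C)C/C=C\CN)[C@H]2OC(C)(C)O[C@H]21` has (octylcarbonyl)amino in place of hydrogen on an aromatic carbon of a six-membered aromatic ring with 2 nitrogen, part of a fused or bridged system of two rings. The counted difference is (octylcarbonyl)amino in place of hydrogen on an aromatic carbon and it is the next change to be read.

For the measured compounds named here, the only measured step that bears on this change is a step that the two limits leave unreadable from compound 1 to compound 2 and it offers no size to carry over. On the size of the entering group alone, a step towards a shorter-lived compound is tentatively expected in this assay for compound 3. The estimated step is an at least 1.6-fold lower number from compound 2 to compound 3 (0.22 log units; that floor lies within the scatter) and it remains loosely held. For compound 3 the estimated half-life is 0.9 h, with an expected range from 0.2 h to 2 h and a real chance that only a limit is reported.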

Compound 3, half-life: 0.162 h
Beside the measured number, compound 3's estimate is 5.6-fold (0.74 log units) above it, and the stated range ends above it.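

In this assay, for the compounds shown here, this aromatic carbon of the six-membered aromatic ring now shows a readable effect of substitution for the first time: placing (octylcarbonyl)amino there in place of hydrogen gives an at least 9.2-fold lower number from compound 2 to compound 3 (0.96 log units; beyond the scatter). Read against the methylamino group of compound 1, the change of octylcarbonyl in place of methyl on the nitrogen gives an at least 9.2-fold lower number from compound 1 to compound 3 (0.96 log units; beyond the scatter), so both comparisons point the same way and both lie beyond the scatter. The step between hydrogen and methylamino on this carbon cannot be read, and compound 3 is the only one of the three with a number rather than a limit: the limit of > 1.5 h in this assay, at which 2 of the 3 values shown sit.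

Going by these compounds, the full size of both steps remains open, and so does whether the lower half-life follows the length of the octyl chain or comes with the amide link itself. An acetylamino group, a longer chain on the same carbonyl, or a plain alkylamine at this carbon would help separate these readings on the shared core.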